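Chlorophenyl piperazine isomers in the cytotoxicity series

The compounds below may be only part of what the source reports. "The series", "measured", "known", "first", "only" and "open" are said of these compounds alone.

Compound 3 `COc1ccc(-c2nnc(N3CCN(C(=O)CN4CCN(c5cccc(Cl)c5)CC4)CC3)nc2-c2ccc(OC)cc2)cc1` is known in a functional assay on MCF7 cells (Homo sapiens) for cytotoxicity, read by MTT assay, with a stated time of 24 h (a higher number here means a weaker inhibitor, a lower number a stronger inhibitor), only as a limit. In this assay compound 3 gives > 814000 nM, which is a limit of the assay and not a number. Compound 1 `COc1ccc(-c2nnc(N3CCN(C(=O)CN4CCN(c5ccccc5Cl)CC4)CC3)nc2-c2ccc(OC)cc2)cc1` gives in this assay > 814000 nM, again a limit. Compound 2 `COc1ccc(-c2nnc(N3CCN(C(=O)CN4CCN(c5cccc(OC)c5)CC4)CC3)nc2-c2ccc(OC)cc2)cc1` gives in this assay > 821000 nM, also a limit. The steps a step that the two limits leave unreadable from compound 1 to compound 2, a step that the two limits leave unreadable from compound 1 to compound 3 and a step that the two limits leave unreadable from compound 2 to compound 3 therefore carry no readable size; all three values sit at the limit of > 814000 nM in this assay, at which 2 of the 3 values shown sit, or (the limit of > 821000 nM in this assay, at which 1 of the 3 values shown sits). Compound 4 `COc1ccc(-c2nnc(N3CCN(C(=O)CN4CCN(c5ccc(Cl)cc5)CC4)CC3)nc2-c2ccc(OC)cc2)cc1` differs from compound 3 by 4-chlorophenyl in place of 3-chlorophenyl on an amine nitrogen in a ring. For the measured compounds named here, no measured step gives a readable size for a change of this kind, and the two earlier changes of aryl group on the same ring nitrogen left compounds 1, 2 and 3 all at their limits. Compound 4 is therefore expected to sit in this assay at or beyond the limit as well, with an estimate of 900000 nM, between 400000 nM and 3000000 nM. The step from compound 3 to compound 4 is accordingly expected to be a step that the limit leaves unreadable from compound 3 to compound 4, no change beyond the scatter.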

Compound 4, half-maximal inhibitory concentration: 607000 nM
Compound 4: middle estimate off by 1.5-fold (0.17 log units), on the high side; the range from low to high includes it.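

In this assay, for the compounds shown here, compound 4, with 4-chlorophenyl on the ring nitrogen, is the only one of the four compounds to give a number rather than a limit, so this change of aryl group gives the series its one measured point. The steps are an at least 1.3-fold lower number from compound 3 to compound 4 (0.12 log units; that floor lies within the scatter), an at least 1.3-fold lower number from compound 2 to compound 4 (0.13 log units; that floor lies within the scatter) and an at least 1.3-fold lower number from compound 1 to compound 4 (0.12 log units; that floor lies within the scatter); these are floors only, and none shows a change beyond the scatter. The steps among compound 1, compound 2 and compound 3 cannot be read, and compound 1 and compound 3 stay at a limit of the assay: the limit of > 814000 nM in this assay, at which 2 of the 4 values shown sit.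

Going by these compounds, what a 4-fluorophenyl or a 4-methoxyphenyl group on the same ring nitrogen gives in this assay stays open. On these data alone, whether the change to 4-chlorophenyl exceeds the scatter also stays open, and settling it needs a number in place of the limit for compound 3.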